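A few compounds are considered here, and "the series" means these few. Any claim that something is new, unique, unknown or untested is made for them only; others in the source may bear on it.

Measured compounds in hand:
Compound 1 `CCOc1nc(N)nc2c1ncn2/C=C1/CC1(CO)CO` — in an ADME assay on HFF cells (Homo sapiens) for cytotoxicity, with a stated time of 8 days (a lower number here means that less compound is tolerated, a higher number that more compound is tolerated), compound 1 gives > 300000 nM, which is a limit of the assay and not a number.
Compound 2 `CCCCCCCCOc1nc(N)nc2c1ncn2/C=C1/CC1(CO)CO` — in this assay compound 2 gives > 300000 nM, again a limit of the assay.
Compound 3 `Nc1nc(NC2CCCCC2)c2ncn(/C=C3/CC3(CO)CO)c2n1` — in this assay compound 3 gives > 300000 nM, once more a limit of the assay.

Where compound 3 stands: only a limit is known for it, and the same holds for the two other compounds, so nothing separates the three in this assay; this is the limit of > 300000 nM in this assay, at which 3 of the 3 values shown sit. The measured steps that touch the same position are a step that the two limits leave unreadable from compound 1 to compound 3 and a step that the two limits leave unreadable from compound 2 to compound 3, and the chain-extension step that the two limits leave unreadable from compound 1 to compound 2 is in the same state: none of them can be read in size or direction.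

The next compound is compound 4 `CCCCNc1nc(N)nc2c1ncn2/C=C1/CC1(CO)CO`. The change from compound 3 is butyl in place of cyclohexyl on a nitrogen on an aromatic ring, the same difference as read from one bond further out being cyclohexylamino to butylamino. For the measured compounds named here, of the measured steps, the two ending at compound 3 bear on it, but both are unreadable, so no size of step in this assay can be derived; no shift beyond the scatter is expected, and a further limit is the most likely outcome. The step from compound 3 to compound 4 is therefore estimated as a number no higher from compound 3 to compound 4 (the limit leaves the size open). Compound 4 is estimated to give 300000 nM, with a range from 150000 nM to 600000 nM.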

Compound 4, half-maximal cytotoxic concentration: > 300000 nM
Compound 4 ended at the assay's limit (the forecaster's own chance of this, stated with the estimate: 85%); the middle value sits exactly at the limit.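

The steps from compound 1, compound 2 and compound 3 to compound 4 cannot be read in size or direction, with all four compounds at one limit of the assay: the limit of > 300000 nM in this assay, at which 4 of the 4 values shown sit.

The compounds shown leave open how the four compare in this assay, and which change on the shared core, if any, would give a measurable half-maximal cytotoxic concentration.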